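The compounds below may be only part of what the source reports. "The series", "measured", "known", "first", "only" and "open" are said of these compounds alone.

Measured so far in a functional assay on MCF7 cells (Homo sapiens) for antiproliferative activity, read by trypan blue exclusion, with a stated time of 24 h; on this read-out lower numbers stand for stronger inhibition and higher numbers for weaker inhibition:
Compound 1, `O=C1NC(=O)/C(=C/c2cn(Cc3ccc([N+](=O)[O-])cc3)c3ccccc23)N1`: 10900 nM
Compound 2, `O=C1NC(=O)/C(=C/c2cn(Cc3ccc(Cl)cc3)c3ccccc23)N1`: 21400 nM

Compound 2 stands alongside compound 1 in this assay: the step of a 2.0-fold higher number from compound 1 to compound 2 (0.29 log units; within the scatter) lies within the scatter, so the two numbers cannot be told apart, and compound 2 gives 21400 nM while compound 1 gives 10900 nM.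

Compound 3, `COC(=O)c1ccc(Cn2cc(/C=C3\NC(=O)NC3=O)c3ccccc32)cc1`, has not yet been measured in this assay. It differs from compound 2 in one place: methoxycarbonyl in place of chloro on an aromatic carbon. Going by the values given here, only one measured step bears on a change at this position, the exchange of one substituent for another on the same aromatic carbon between compound 1 and compound 2, and that step, a 2.0-fold higher number from compound 1 to compound 2 (0.29 log units; within the scatter), stayed within the scatter. On this evidence no step beyond the scatter is expected in this assay for compound 3, in either direction; the number is expected to sit near the two known values. Compound 3 is therefore estimated at 15000 nM, with a range from 6000 nM to 40000 nM. The step of a 1.4-fold lower number from compound 2 to compound 3 (0.15 log units; within the scatter) that this estimate means is expected to remain within the scatter.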

Compound 3, half-maximal inhibitory concentration: 15400 nM
Compound 3: the middle estimate sits 1.0-fold (0.01 log units) below what was measured, and the stated range covers the measured number.
By their numbers in this assay, from the lowest: compounds 1, 3 and 2 (each within the scatter of the next).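

In this assay, methoxycarbonyl in place of chloro, on an aromatic carbon para to a large group, gives a 1.4-fold lower number from compound 2 to compound 3 (0.14 log units; within the scatter) and the same group in place of nitro gives a 1.4-fold higher number from compound 1 to compound 3 (0.15 log units; within the scatter) so the position has now taken a third substituent without any step leaving the scatter. The earlier pair offered a single exchange, whereas these compounds show that the read-out also fails to separate chloro, with its 1 heavy atom and 0 hydrogen-bond acceptors, from methoxycarbonyl, with 4 heavy atoms, 2 hydrogen-bond acceptors and a double bond outside aromatic rings, so across these three compounds neither count goes with a step beyond the scatter. No measurement at hand offers an explanation for this result.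

From the compounds shown here alone, whether an amine, a carboxylic acid or a longer chain at this same position would also stay within the scatter remains open. The compounds also leave open how a bare hydrogen there would compare with these three groups, and whether changes elsewhere on the shared core would move the number further than any exchange seen here.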